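Thromboxane synthase inhibition: varying the group on the ring nitrogen

The source may report more compounds than this note shows. Statements on the series, on what has been measured and on what is new or still open speak of the compounds shown alone.

Measured compounds:
Compound 1 `CCCCn1nc(-c2cccnc2)c2ccccc2c1=O` — 91%
Compound 2 `O=c1c2ccccc2c(-c2cccnc2)nn1C1CCCC1` — 97%
Compound 3 `COC(=O)c1ccc(Cn2nc(-c3cccnc3)c3ccccc3c2=O)cc1` — 95%

Three compounds share one core and differ only in the group attached to an aromatic nitrogen of that core. Going by the values given here, in an assay on isolated protein (Oryctolagus cuniculus) with Thromboxane-A synthase (Homo sapiens) as the target, tested at 1 uM (on this read-out lower numbers stand for less inhibition and higher numbers for more inhibition at the one concentration tested (going by the name of the read-out)), compound 2 gives 97%, the highest of the three numbers; compound 3 sits nearest with 95% and compound 1 furthest with 91%, yet both gaps lie within the scatter, so no compound can be called stronger than another.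

Compound 4 `O=c1c2ccccc2c(-c2cccnc2)nn1CCSc1nccs1` has not been measured. It differs from compound 2 in one place: 2-((1,3-thiazol-2-yl)sulfanyl)ethyl in place of cyclopentyl on an aromatic nitrogen.

Among the compounds with values here, only one measured step concerns the group on this aromatic nitrogen, the change from butyl to cyclopentyl, which gave a number 6 percentage points higher from compound 1 to compound 2 (within the scatter). The benzyl-type group of compound 3 also left the number high. Within the data shown here, no step shows what a sulfur-linked thiazole chain does, so the expectation rests on the fact that three different groups at this place all gave high inhibition.

For compound 4 a step of a number 7 percentage points lower from compound 2 to compound 4 (within the scatter) is expected, a small drop lying within the scatter. Compound 4 is thus estimated at 90%, between 75% and 98%.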

Compound 4, a percentage reported as inhibition, at one concentration (the size of the read-out at that concentration, not a potency): 97%
Compound 4: middle estimate off by 7 percentage points, on the low side; measured number inside the range.
By their numbers in this assay, from the lowest: compounds 1, 3, 2 and 4 (each within the scatter of the next).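

In this assay, replacing cyclopentyl with 2-((1,3-thiazol-2-yl)sulfanyl)ethyl on the aromatic nitrogen gives no change at the digits printed from compound 2 to compound 4 (within the scatter), so this position also accepts a flexible chain carrying a five-membered aromatic ring with 2 hetero atoms and 3 hydrogen-bond acceptors, where cyclopentyl has none. Compared with the plain butyl chain, placing (1,3-thiazol-2-yl)sulfanyl in place of ethyl on the chain gives a number 6 percentage points higher from compound 1 to compound 4 (within the scatter), so extending the chain with this sulfur-linked ring leaves no change that can be told apart from the scatter. No measurement here explains why inhibition stays high across these different groups.

As far as these compounds go, whether a chain ending in an amine or a carboxylic acid, or a bare hydrogen on this nitrogen, would keep the number this high remains open. From the compounds shown here alone, because all four compounds were compared at one concentration and lie within the scatter of one another, any difference in potency among them also remains open.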